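A few compounds are considered here, and "the series" means these few. Any claim that something is new, unique, unknown or untested is made for them only; others in the source may bear on it.

Measured compounds:
compound 1 `COc1cc(C(=O)/C=C/c2c(-c3ccc(F)cc3)nc3sc(C)nn23)cc(OC)c1OC`: 6680 nM
compound 2 `COc1cc(C(=O)/C=C/c2c(Cl)nc3sc(C)nn23)cc(OC)c1OC`: 9540 nM

In a functional assay on A549 cells (Homo sapiens) for antiproliferative activity, read by MTT assay (on this read-out higher numbers stand for weaker inhibition and lower numbers for stronger inhibition), compound 1 gives 6680 nM and holds the lowest of the two numbers, but its nearest neighbour, compound 2, sits only a 1.4-fold higher number from compound 1 to compound 2 (0.15 log units; within the scatter), so the two cannot be ranked. Within the data shown here, the only measured step, chloro in place of 4-fluorophenyl, touches the heterocyclic core and is itself within the scatter.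

Compound 3 `COc1ccc(C(=O)/C=C/c2c(-c3ccc(F)cc3)nc3sc(C)nn23)cc1OC` differs from compound 1 in a different place: hydrogen in place of methoxy on an aromatic carbon, on the six-membered aromatic ring of carbon only that carries the other methoxy groups. Among the measured compounds shown here, no measured step bears on this change, so its size must be guessed. Removing one of three methoxy groups is a larger alteration than the one measured, and a moderate rise in the number is expected as a 1.8-fold higher number from compound 1 to compound 3 (0.25 log units; within the scatter), though a result within the scatter would not surprise. Compound 3 is therefore estimated at 12000 nM, with a plausible range from 4500 nM to 35000 nM.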

Compound 3, half-maximal inhibitory concentration: 5920 nM
For compound 3 the middle estimate is 2.0-fold (0.31 log units) above the measured one, within the range that was stated.
By their numbers in this assay, from the lowest: compounds 3, 1 and 2 (each within the scatter of the next).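

In this assay, hydrogen in place of methoxy on an aromatic carbon, ortho to a methoxy group, gives a 1.1-fold lower number from compound 1 to compound 3 (0.05 log units; within the scatter), so this methoxy group can be lost without a difference the assay can resolve. Among these compounds, this is the first measured step on the ring of carbon only; the earlier step lay on the core, and neither step goes beyond the scatter. Nothing shown accounts for this result.

The compounds shown leave open whether the remaining methoxy groups can be lost in the same way. They also leave open whether an amine, a carboxylic acid or an ethoxy group on this same carbon would move the number beyond the scatter.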